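Pyrazolyl in place of pyridyl on the biaryl arm

The compounds below may be only part of what the source reports. "The series", "measured", "known", "first", "only" and "open" are said of these compounds alone.

Measured so far in a functional assay on HEK293 cells for agonist activity at Bombesin receptor subtype-3 (Homo sapiens), read by luminescence and calcium flux, with a stated time of 10 min; a lower number here means that less compound is needed, a higher number that more compound is needed for the effect:
- compound 1 `c1ccc(-c2ccc(CCc3nc(CC4CCCC4)c[nH]3)cc2)nc1` gives 425 nM
- compound 2 `CCC(C)(C)Cc1c[nH]c(CCc2ccc(-c3cccnc3)cc2)n1` gives 131 nM
- compound 3 `O=C(O)c1cc(F)c(F)cc1-c1ccc(CCc2nc(CC3CCCCC3)c[nH]2)cc1` gives 63 nM

Compound 2 holds the second highest of these three numbers. Its nearest neighbour is compound 3, whose number is lower by a margin beyond the scatter; compound 1 sits furthest off, higher by a margin also beyond the scatter.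

Compound 4 `CCC(C)(C)Cc1c[nH]c(CCc2ccc(-n3cccn3)cc2)n1` is not yet measured. It differs from compound 2 in one place: 1H-pyrazol-1-yl in place of pyridin-3-yl on an aromatic carbon. Among the compounds with values here, the measured set gives no directly comparable step, so the expectation rests on the spread already seen across the three aryl variants. A modest rise in the number is expected for compound 4, estimated as a 1.9-fold higher number from compound 2 to compound 4 (0.28 log units; within the scatter). Compound 4 is estimated at 250 nM, within 100 nM to 700 nM.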

Compound 4, half-maximal effective concentration: 135 nM
Compound 4: the middle estimate sits 1.9-fold (0.27 log units) above what was measured; the measured number falls inside the stated range.
By their numbers in this assay, from the lowest: compound 3; then compounds 2 and 4 (each within the scatter of the next); then compound 1.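

In this assay, within the data shown here, 1H-pyrazol-1-yl in place of pyridin-3-yl gives a 1.0-fold higher number from compound 2 to compound 4 (0.01 log units; within the scatter), the first single-place comparison. On this aromatic carbon, para to a large group, a five-membered aromatic ring with 2 hetero atoms and a six-membered aromatic ring with 1 hetero atom cannot be told apart by their numbers. No available data offer an explanation for this.

Open, as far as these compounds go, is whether a morpholine or a primary amide at this place would keep the number. Also open, from the compounds shown here alone, is whether the same exchange reads alike on the core of compound 1.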